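From methoxy to fluoro on a shared core

A few compounds are considered here, and "the series" means these few. Any claim that something is new, unique, unknown or untested is made for them only; others in the source may bear on it.

Compound 1 `O=c1n(Cc2cc3cc(Cl)ccc3n2CCCCO)c2cnccc2n1C1CC1` reaches in an ADME assay on HeLa cells (Homo sapiens) for cytotoxicity, read by ATP content, with a stated time of 3 days (on this read-out lower numbers stand for higher toxicity in this test and higher numbers for lower toxicity in this test), only a limit, > 50000 nM. Compound 2 `COc1ccc2c(c1)cc(Cn1c(=O)n(C3CC3)c3ccncc31)n2CCCCO` likewise reaches in this assay only a limit, > 50000 nM. The step that the two limits leave unreadable from compound 1 to compound 2 cannot be read because of the limit of > 50000 nM in this assay, at which 2 of the 2 values shown sit. Compound 2 therefore stands at the limit, without a number of its own. Compound 3 `O=c1n(Cc2cc3cc(F)ccc3n2CCCCO)c2cnccc2n1C1CC1` differs from compound 2 by fluoro in place of methoxy on an aromatic carbon. Among the measured compounds shown here, the single measured step touches the same aromatic carbon yet is unreadable, so it sets no direction. Compound 3 is expected to sit at the limit again, with an estimated 80000 nM between 40000 nM and 200000 nM. The step that the limit leaves unreadable from compound 2 to compound 3 is thus expected to be none beyond the scatter.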

Compound 3, half-maximal cytotoxic concentration: > 50000 nM
Compound 3: no number, only a limit (the forecaster's own chance of this, stated with the estimate: 85%); the middle value lies beyond the limit too.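

Among the compounds shown here, no step among compound 1, compound 2 and compound 3 can be read in this assay, because all three rest on a limit: the limit of > 50000 nM in this assay, at which 3 of the 3 values shown sit. The compounds shown leave open whether chloro, methoxy and fluoro differ at all in this assay.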